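The source may report more compounds than this note shows. Statements on the series, on what has been measured and on what is new or still open speak of the compounds shown alone.

In a functional assay on EOL1 cells (Homo sapiens) for inhibition, read by fluorescence, with a stated time of 72 h (on this read-out higher numbers stand for weaker inhibition of growth and lower numbers for stronger inhibition of growth), compound 1 `COc1ccc(Nc2nc(N[C@H]3CC[C@H](N)CC3)nc3c2ncn3CCC(C)C)c(OC)c1` gives 630 nM, within the scatter of compound 2 `COc1ccc(Cn2cnc3c(Nc4cccc(Cl)c4)nc(N[C@H]4CC[C@H](N)CC4)nc32)cc1` at 530 nM, while compound 3 `CCCCCCn1cnc2c(Nc3cccc(Cl)c3)nc(N[C@H]3CC[C@H](N)CC3)nc21`, at 310 nM, lies lower than compound 1 by more than the scatter. Compound 4 `CC(C)CCn1cnc2c(Nc3cccc(O)c3)nc(N[C@H]3CC[C@H](N)CC3)nc21` differs from compound 1 on a nitrogen on an aromatic ring, with 3-hydroxyphenyl in place of 2,4-dimethoxyphenyl (3-hydroxyphenyl in place of 2,4-dimethoxyphenyl on a nitrogen on an aromatic ring). Within the data shown here, no measured step changes this group. Among the measured compounds shown here, the only step available, a 1.7-fold lower number from compound 2 to compound 3 (0.23 log units; within the scatter), concerns another place and stays within the scatter, so it bears only indirectly. With a different aromatic group at this place, compound 3 reads 310 nM, which points to lower numbers. A modest step is therefore expected, a 2.1-fold lower number from compound 1 to compound 4 (0.32 log units; beyond the scatter). For compound 4 the estimated value is 300 nM, with an expected range from 80 nM to 1000 nM.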

Compound 4, concentration for 50% growth inhibition: 60 nM
Estimate against measurement, compound 4: 5.0-fold (0.70 log units) above, and the stated range ends above it.
By their numbers in this assay, from the lowest: compound 4; then compounds 3, 2 and 1 (each within the scatter of the next, the first and the last beyond it).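

Placing 3-hydroxyphenyl where compound 1 carries 2,4-dimethoxyphenyl, on a nitrogen on an aromatic ring, gives in this assay an 11-fold lower number from compound 1 to compound 4 (1.02 log units; beyond the scatter), showing a large response at a place that no earlier step had touched. The change replaces two methoxy groups with one hydroxyl, and this single step cannot apportion the gain among those differences. No evidence here accounts for the size of the step. Still open, from the compounds shown here alone, is whether the hydroxyl itself matters, which 3-methoxyphenyl or 3-aminophenyl at this place, with the rest of compound 4 unchanged, would address.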